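The source may hold more compounds than are shown below. What is called first, only, known or untested is meant among the compounds shown, and "the series" means these compounds.

Compound 1 `Cc1cc(N2CCC[C@H](COCc3nc(C)no3)C2)c2c(N)c(C(N)=O)sc2n1` carries a methyl on the shared core. In an ADME assay on the whole organism (Rattus norvegicus, strain Fischer 344) for pharmacokinetics, with a stated time of 8 h, at a dose of 3 mg/kg by the oral route (on this read-out lower numbers stand for lower exposure and higher numbers for higher exposure at the dose given), compound 1 gives 722 ng.h/mL; of the three numbers at hand it is the lowest, though compound 2 `NC(=O)c1sc2nccc(N3CCC[C@H](COCC(=O)N4CCOCC4)C3)c2c1N`, which gives 756 ng.h/mL, sits within the scatter of it, and only compound 3 `CCOCCOC[C@H]1CCCN(c2ccnc3sc(C(N)=O)c(N)c23)C1`, with 2000 ng.h/mL, stands apart beyond the scatter. Among the measured compounds shown here, the only step measured between compounds differing in one place is a 2.6-fold higher number from compound 2 to compound 3 (0.42 log units; beyond the scatter), and that step concerns the chain, not the core.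

Compound 4 `Cc1noc(COC[C@H]2CCCN(c3ccnc4sc(C(N)=O)c(N)c34)C2)n1` differs from compound 1 by hydrogen in place of methyl on an aromatic carbon. For the measured compounds named here, no measured pair alters this position on the core, so the series gives no direct guide for the change; the chain of compound 1 is kept in compound 4. With nothing to point either way, the expectation is a step of a 1.0-fold lower number from compound 1 to compound 4 (0.01 log units; within the scatter), no shift beyond the scatter. Compound 4 is therefore estimated to give 700 ng.h/mL in this assay, with a range from 300 ng.h/mL to 1600 ng.h/mL.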

Compound 4, area under the concentration-time curve: 563 ng.h/mL
Estimate against measurement, compound 4: 1.2-fold (0.09 log units) above; measured number inside the range.
By their numbers in this assay, from the lowest: compounds 4, 1 and 2 (each within the scatter of the next); then compound 3.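

In this assay, hydrogen in place of methyl on the aromatic carbon next to the ring nitrogen, with the 3-methyl-1,2,4-oxadiazol-5-yl chain unchanged, gives a step within the scatter (a 1.3-fold lower number from compound 1 to compound 4 (0.11 log units; within the scatter)), so the methyl does not separate this pair. With hydrogen at this position in compounds 2, 3 and 4, the chain ends can now be read on one core: the ethoxymethyl end stands apart from the 3-methyl-1,2,4-oxadiazol-5-yl end (a 3.6-fold lower number from compound 3 to compound 4 (0.55 log units; beyond the scatter)), whereas the (morpholin-4-yl)carbonyl end does not (a 1.3-fold lower number from compound 2 to compound 4 (0.13 log units; within the scatter)). No measurement at hand bears on the reason for any of these steps.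

Open, as far as these compounds go, is whether an amine or a methoxy group at this aromatic carbon would give a step beyond the scatter. Also open, from the compounds shown here alone, is whether methyl in place of hydrogen at this position would give a similar step with the ethoxymethyl end of compound 3.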